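A few compounds are considered here, and "the series" means these few. Any claim that something is new, unique, unknown or untested is made for them only; others in the source may bear on it.

Compound 1 `CN(C)C(=O)c1cc2cnc(Nc3ccc(NC(=O)C4(C(=O)Nc5ccc(Cl)c(C(F)(F)F)c5)CC4)cc3)nc2n1C1CCCC1` stands lowest of the three measured compounds in a functional assay on A549 cells (Homo sapiens) for inhibition, read by CCK-8 assay, with a stated time of 72 h, tested at 1 uM (a lower number here means less inhibition of growth, a higher number more inhibition of growth at the concentration tested), where compound 1 gives 1.1%. Its nearest neighbour is compound 2 `CN(C)C(=O)c1cc2cnc(Nc3ccc(NC(=O)C4(C(=O)Nc5cccc(Cl)c5)CC4)cc3)nc2n1C1CCCC1`, which in this assay gives 8.3%; the step of a number 7.2 percentage points higher from compound 1 to compound 2 (within the scatter) lies within the scatter. Furthest away is compound 3 `Cc1ccc(NC(=O)C2(C(=O)Nc3ccc(Nc4ncc5cc(C(=O)N(C)C)n(C6CCCC6)c5n4)cc3)CC2)cc1`, which in this assay gives 40.2%; the step of a number 39.1 percentage points higher from compound 1 to compound 3 (beyond the scatter) lies well beyond the scatter, and so does the step of a number 31.9 percentage points higher from compound 2 to compound 3 (beyond the scatter).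

Compound 4 `COC(=O)c1cccc(NC(=O)C2(C(=O)Nc3ccc(Nc4ncc5cc(C(=O)N(C)C)n(C6CCCC6)c5n4)cc3)CC2)c1` has not yet been tested in this assay. It differs from compound 1 in one place: 3-(methoxycarbonyl)phenyl in place of 4-chloro-3-(trifluoromethyl)phenyl on an amide-type nitrogen. Both measured steps from compound 1 bear on this change, since each also replaces the 4-chloro-3-(trifluoromethyl)phenyl on the same amide-type nitrogen. One of them, a number 7.2 percentage points higher from compound 1 to compound 2 (within the scatter), is small; the other, a number 39.1 percentage points higher from compound 1 to compound 3 (beyond the scatter), is large. Among the compounds with values here, no measured compound carries a methoxycarbonyl on this ring, so the new group has no direct precedent among the three. Weighing the small and the large step together, a modest rise from compound 1 to compound 4 in this assay is expected, of about a number 13.9 percentage points higher from compound 1 to compound 4 (beyond the scatter). Compound 4 is therefore estimated at 15%, with a range from 0% to 40%.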

Compound 4, percent growth inhibition at one concentration: 10.5%
For compound 4 the middle estimate is 4.5 percentage points above the measured one, and the stated range covers the measured number.
By their numbers in this assay, from the lowest: compounds 1, 2 and 4 (each within the scatter of the next); then compound 3.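

In this assay the 3-(methoxycarbonyl)phenyl on the amide-type nitrogen stays within the scatter of the two chloro-bearing rings: the exchange for 4-chloro-3-(trifluoromethyl)phenyl is a number 9.4 percentage points higher from compound 1 to compound 4 (within the scatter), and methoxycarbonyl in place of chloro on an aromatic carbon is a number 2.2 percentage points higher from compound 2 to compound 4 (within the scatter). The earlier compounds shown here left open whether removing chloro from this ring was enough to bring the higher number, but compound 4 carries neither chloro nor trifluoromethyl and still does not stand apart from those two. Of the four rings, only the 4-methylphenyl of compound 3 stands apart, and the exchange for 3-(methoxycarbonyl)phenyl is a number 29.7 percentage points lower from compound 3 to compound 4 (beyond the scatter), so here the high number goes with that one ring and not with the absence of chloro.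

Nothing at hand explains why this one ring differs from the other three. On these data alone, it also remains open whether an ethyl group in place of the methyl of the 4-methylphenyl would keep the number of compound 3, and whether a carboxylic acid in place of the methoxycarbonyl would move the number of compound 4.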